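From chloro to trifluoromethyl at compound 4

The source may report more compounds than this note shows. Statements on the series, on what has been measured and on what is new or still open speak of the compounds shown alone.

Compound 1 `CCNCC1CCN(c2c(F)cc3c(=O)c(C(=O)O)cn(C4CC4)c3c2C(F)(F)F)C1`: 120 ug/mL
Compound 2 `CC1CN(c2c(F)cc3c(=O)c(C(=O)O)cn(C4CC4)c3c2C(F)(F)F)CC(C)N1`: > 500 ug/mL
Compound 3 `NC1CCN(c2c(F)cc3c(=O)c(C(=O)O)cn(C4CC4)c3c2Cl)CC1`: 18 ug/mL

In a functional assay on V79 cells (Cricetulus griseus) for cytotoxicity, read by colony formation (on this read-out higher numbers stand for weaker inhibition and lower numbers for stronger inhibition), compound 3 gives the lowest number, and compound 1 lies beyond the scatter from it. The entry for compound 2 is a limit, not a number. Compound 4 `NC1CCN(c2c(F)cc3c(=O)c(C(=O)O)cn(C4CC4)c3c2C(F)(F)F)CC1` carries trifluoromethyl in place of chloro on an aromatic carbon. Among the compounds with values here, the only measured step, an at least 4.1-fold higher number from compound 1 to compound 2 (0.61 log units; beyond the scatter), puts 3,5-dimethylpiperazin-1-yl in place of 3-((ethylamino)methyl)pyrrolidin-1-yl, so it bears on this change only indirectly: both compounds keep trifluoromethyl. Compound 1, with trifluoromethyl but a different amino group, gives 120 ug/mL. A modest rise in this assay is therefore expected, a 2.5-fold higher number from compound 3 to compound 4 (0.40 log units; beyond the scatter). For compound 4 the estimated value is 45 ug/mL, with an expected range of 15 ug/mL to 150 ug/mL.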

Compound 4, half-maximal inhibitory concentration: 20 ug/mL
Compound 4: middle estimate off by 2.3-fold (0.35 log units), on the high side; low and high end bracket the measured number.
By their numbers in this assay, from the lowest: compounds 3 and 4 (each within the scatter of the next); then compound 1. At a limit, above all of these: compound 2.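

In this assay, trifluoromethyl in place of chloro on this aromatic carbon, ortho to a 4-aminopiperidin-1-yl group, gives a 1.1-fold higher number from compound 3 to compound 4 (0.05 log units; within the scatter), so the two groups cannot be told apart with this amino group in place. With trifluoromethyl kept, the amino group does shift the number: a 6.0-fold lower number from compound 1 to compound 4 (0.78 log units; beyond the scatter), and an at least 25-fold lower number from compound 2 to compound 4 (1.39 log units; beyond the scatter). The second of these steps starts from a limit held by compound 2: the limit of > 500 ug/mL in this assay, at which 1 of the 4 values shown sits.

Going by these compounds, whether a methyl or a nitrile on this carbon would also stay within the scatter remains open. So does whether chloro and trifluoromethyl would also match with 3,5-dimethylpiperazin-1-yl in place of 4-aminopiperidin-1-yl.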